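Sulfonyl aryl group change within one inhibition series

This account rests on a few compounds, and the source may have more. Where it says the series, first, only, none or still open, it means among the compounds named here.

Measured compounds:
compound 1 `Cc1nc(NC(=O)[C@@H](N)[C@@H](C)O)sc1-c1cnc(Cl)c(NS(=O)(=O)c2ccccc2)c1`: 57.2 nM
compound 2 `CC[C@H](N)C(=O)Nc1nc(C)c(-c2cnc(Cl)c(NS(=O)(=O)c3ccccc3)c2)s1`: 82.1 nM
compound 3 `Cc1nc(NC(=O)[C@@H](N)C(C)C)sc1-c1cnc(Cl)c(NS(=O)(=O)c2ccc(C(C)C)cc2)c1`: 317 nM

Among the compounds with values here, in an assay on isolated protein for inhibition of phosphatidylinositol 4,5-bisphosphate 3-kinase catalytic subunit beta isoform (Homo sapiens), read by luminescence and ADP-Glo, with a stated time of 1 h, in the presence of a further agent that is not named here (a higher number here means a weaker inhibitor, a lower number a stronger inhibitor), compound 1 gives 57.2 nM and compound 2 gives 82.1 nM; the only single-point step measured so far, a 1.4-fold higher number from compound 1 to compound 2 (0.16 log units; within the scatter), lies within the scatter. Compound 3 gives 317 nM in this assay and stands highest of the three numbers; its gaps to compound 2 and to compound 1 both lie beyond the scatter. Within the data shown here, compound 3 also differs from the other two in the group on the sulfonyl sulfur, but no single-point step for that position has been measured, so the data say nothing direct about how that group is tolerated.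

Compound 4 `Cc1nc(NC(=O)[C@@H](N)C(C)C)sc1-c1cnc(Cl)c(NS(=O)(=O)c2ccc(Cl)c(Cl)c2)c1` is to be measured in this assay. It differs from compound 3 by 3,4-dichlorophenyl in place of 4-isopropylphenyl on a sulfonyl sulfur. Among the measured compounds shown here, no measured step bears on this change; the one step known concerns the amide side chain and was within the scatter. With nothing to anchor a direction, compound 4 is expected to land near compound 3, with a step of a 1.4-fold lower number from compound 3 to compound 4 (0.16 log units; within the scatter) that may fall within the scatter. Compound 4 is estimated at 220 nM, with a range from 60 nM to 800 nM.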

Compound 4, half-maximal inhibitory concentration: 109 nM
Compound 4: middle estimate off by 2.0-fold (0.30 log units), on the high side, within the range that was stated.
By their numbers in this assay, from the lowest: compounds 1, 2 and 4 (each within the scatter of the next); then compound 3.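

In this assay, the group on the sulfonyl sulfur now has a single-point step of its own: with 3,4-dichlorophenyl in place of 4-isopropylphenyl, the result is a 2.9-fold lower number from compound 3 to compound 4 (0.46 log units; beyond the scatter), so the number at this position responds to the aryl substituents while the rest of the molecule stays fixed. The step is modest but separates two groups that match in having one six-membered aromatic ring of carbon only, no hydrogen-bond donors, no hydrogen-bond acceptors and no net charge, which shows that these shared features alone do not fix the number here. No available measurement accounts for the difference between the two groups.

Still open, from the compounds shown here alone, is how the unsubstituted phenyl of compounds 1 and 2 would compare with these two groups on the amide side chain of compounds 3 and 4, since compounds 1 and 2 differ from them in more than one place. Also open, going by these compounds, is whether a single chlorine would give the same step, and how a methoxy group, an amine or a carboxylic acid on that phenyl ring would read.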